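Moving the chlorine on the urea-linked phenyl ring

The source may report more compounds than this note shows. Statements on the series, on what has been measured and on what is new or still open speak of the compounds shown alone.

Compound 1, `COc1cccc(NC(=O)NC2CC(C)(C)Oc3ccc(Br)cc32)c1`, gives in a functional assay (aorta) with Rattus norvegicus as the target (on this read-out lower numbers stand for an effect already at smaller amounts and higher numbers for an effect only at larger amounts of compound), only the assay limit > 10000 nM.
Compound 2, `COc1ccc(NC(=O)NC2CC(C)(C)Oc3ccc(Br)cc32)cc1`, gives in this assay only the assay limit > 10000 nM.
Compound 3, `CC1(C)CC(NC(=O)Nc2ccccc2Cl)c2cc(Br)ccc2O1`, gives in this assay only the assay limit > 30000 nM.

Going by the values given here, compound 3 therefore stands at a limit rather than at a number, and the two other values in this assay are limits as well, so no compound in this set has a readable position. The three steps among them, a step that the two limits leave unreadable from compound 1 to compound 2, a step that the two limits leave unreadable from compound 1 to compound 3 and a step that the two limits leave unreadable from compound 2 to compound 3, are all left unreadable by the limits; what can be said is summed up by the limit of > 10000 nM in this assay, at which 2 of the 3 values shown sit, and (the limit of > 30000 nM in this assay, at which 1 of the 3 values shown sits).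

Compound 4, `CC1(C)CC(NC(=O)Nc2ccc(Cl)cc2)c2cc(Br)ccc2O1`, differs from compound 3 by 4-chlorophenyl in place of 2-chlorophenyl on an amide-type nitrogen. None of the measured steps gives a readable size, so the expectation for compound 4 in this assay rests on the fact that every compound shown so far sits at a limit. Compound 4 is estimated to give 30000 nM, with a range from 5000 nM to 100000 nM, and most likely to be reported as a limit again. The step of a number no higher from compound 3 to compound 4 (the limit leaves the size open) is expected to be no more than the scatter, with a limit the likeliest outcome.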

Compound 4, half-maximal effective concentration: > 300000 nM
Compound 4 ended at the assay's limit; the forecaster's own chance of this, stated with the estimate: 80%; at least 10-fold (1.00 log units) between middle value and limit.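

In this assay compound 4 gives > 300000 nM, which is a limit of the assay and not a number. Going by these compounds alone, its steps from compound 1, compound 2 and compound 3 cannot be read, so this result adds no new step. The compounds shown leave open whether 4-chlorophenyl and 2-chlorophenyl differ at all, and what effective concentration any of these compounds has.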